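The source may report more compounds than this note shows. Statements on the series, on what has been measured and on what is new or still open speak of the compounds shown alone.

Series notes. For the measured compounds named here, compound 1 `CN1CCN(c2ccc(/C=C3/SC(Nc4ccccc4)=NC3=O)cc2)CC1` is the reference point: in a functional assay on NCI-H460 cells (Homo sapiens) for cytotoxicity, read by sulforhodamine B assay, with a stated time of 48 h (on this read-out higher numbers stand for an effect only at larger amounts of compound and lower numbers for an effect already at smaller amounts), compound 1 gives 1400 nM, the only plain number among the three values recorded so far. Compound 2 `O=C1N=C(Nc2ccccc2)S/C1=C/c1ccc(N2CCNCC2)cc1` carries hydrogen in place of methyl on the amine nitrogen in the ring. Compound 2 reaches only a limit of the assay, > 100000 nM. That single change gives an at least 71-fold higher number from compound 1 to compound 2 (1.85 log units; beyond the scatter). Going by the values given here, compound 3 `CN(C)c1ccc(/C=C2/SC(N(c3ccccc3)c3ccccc3)=NC2=O)cc1` differs from compound 1 in two places, so no single step connects them. Compound 3 likewise reaches only a limit, > 100000 nM. Both of these fall at the limit of > 100000 nM in this assay, at which 2 of the 3 values shown sit.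

Compound 4 `CN1CCN(c2ccc(/C=C3/SC(N(c4ccccc4)c4ccccc4)=NC3=O)cc2)CC1` is the next target: phenyl in place of hydrogen on a nitrogen on an aromatic ring. Among the compounds with values here, no measured step covers this change on its own. The step from compound 1 to compound 2 concerns a different position and does not bear on it. Within the data shown here, compound 3 is the only compound that already carries phenyl on that nitrogen, and it is read only as a limit in this assay. On that basis the expectation for compound 4 is a large rise in this assay, most likely up to the limit, which amounts to an estimated step of a 43-fold higher number from compound 1 to compound 4 (1.63 log units; beyond the scatter). Compound 4 is therefore estimated at 60000 nM, within 8000 nM to 300000 nM, with a fair chance that only a limit is reported.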

Compound 4, half-maximal effective concentration: > 100000 nM
Compound 4 gave a limit, no number; the forecaster's own chance of this, stated with the estimate: 60%; at least 1.6-fold (0.22 log units) between middle value and limit.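

In this assay, phenyl in place of hydrogen on the nitrogen on an aromatic ring, with the 4-methylpiperazin-1-yl group kept, gives an at least 71-fold higher number from compound 1 to compound 4 (1.85 log units; beyond the scatter). For the compounds shown here, this is the first single-change reading at this nitrogen: compound 3 also carries phenyl there but differs from compound 1 in two places, so its limit alone could not be assigned to either change, whereas compound 4 shows that the 4-methylpiperazin-1-yl group does not preserve the measurable value of compound 1 once phenyl is present. The step from compound 3 to compound 4 cannot be read, and the series now gathers at one end of the scale: the limit of > 100000 nM in this assay, at which 3 of the 4 values shown sit.

Only hydrogen and phenyl are seen on this nitrogen, and a methyl or ethyl group there remains unread, leaving open whether any replacement of that hydrogen is compatible with a measurable value. On these data alone, how far compound 4 lies beyond the limit also remains open, as does whether a substituent such as methoxy on the added phenyl would change the reading.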